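Bulkier chain on a shared core: the next methyl

The source may hold more compounds than are shown below. What is called first, only, known or untested is meant among the compounds shown, and "the series" means these compounds.

Among the compounds with values here, compound 3 `CC(C)C(C)(C)/N=C(\NC#N)Nc1ccncc1` has the second highest number among the three compounds measured so far in a functional assay on the whole organism (blood, strain Wistar-Okamoto) with Rattus norvegicus as the target, with a stated time of 5 days; a higher number here means that more compound is needed for the effect, a lower number that less compound is needed. In this assay compound 3 needs 20 mg/kg, while compound 2 `CCC(C)(C)/N=C(\NC#N)Nc1ccncc1` needs 2.5 mg/kg and compound 1 `CC(C)(C)C(C)(C)/N=C(\NC#N)Nc1cccnc1` needs 50 mg/kg. Within the data shown here, the one step that compares directly runs an 8.0-fold higher number from compound 2 to compound 3 (0.90 log units; beyond the scatter). Compound 4 `CC(C)(C)C(C)(C)/N=C(\NC#N)Nc1ccncc1` takes the same direction one notch further: methyl in place of hydrogen on a saturated chain carbon bound to three saturated chain carbons. Among the measured compounds shown here, because the measured step of an 8.0-fold higher number from compound 2 to compound 3 (0.90 log units; beyond the scatter) showed that adding a methyl at this chain position raised the dose needed, a further rise is expected here too, though with only one such step to lean on its size is uncertain and may be smaller or larger. Compound 1 carries the same chain end as compound 4 but on a different core, so its value is only loose support. Compound 4 is therefore estimated at 50 mg/kg, within a range of 15 mg/kg to 160 mg/kg, which means an expected step of a 2.5-fold higher number from compound 3 to compound 4 (0.40 log units; beyond the scatter).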

Compound 4, minimum effective dose: 20 mg/kg
Compound 4: middle estimate off by 2.5-fold (0.40 log units), on the high side; the range from low to high includes it.
By their numbers in this assay, from the lowest: compound 2; then compounds 3 and 4 (each within the scatter of the next); then compound 1.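

In this assay, the change from isopropyl to tert-butyl gives no change at the digits printed from compound 3 to compound 4 (within the scatter) and so does not repeat the rise that the previous methyl produced. The full change from ethyl to tert-butyl gives an 8.0-fold higher number from compound 2 to compound 4 (0.90 log units; beyond the scatter) and matches an 8.0-fold higher number from compound 2 to compound 3 (0.90 log units; beyond the scatter) in size, which places the whole rise among these three compounds at the first added methyl. With the tert-butyl end held fixed, pyridin-4-yl in place of pyridin-3-yl on an amine nitrogen gives a 2.5-fold lower number from compound 1 to compound 4 (0.40 log units; beyond the scatter) and shows that the dose can still move with the core when this methyl leaves it flat. Nothing available explains why the first methyl raises the dose and the second does not. On these data alone, it remains open whether a longer chain or a chain ending in an amine at this place would stay level with compound 4 or shift the dose again.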